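The source may hold more compounds than are shown below. What is called first, only, known or untested is meant among the compounds shown, and "the series" means these compounds.

Among the compounds with values here, compound 1 `O=C(Nc1cc(-c2ccccc2)nn1-c1ccccc1)c1ccccc1` gives 203 nM in a functional assay on cells for positive allosteric modulation of metabotropic glutamate receptor 5 (Rattus norvegicus), read by calcium flux (a lower number here means that less compound is needed, a higher number that more compound is needed for the effect), the highest of the three numbers so far. Compound 2 `O=C(Nc1cc(-c2ccccc2)nn1-c1ccccc1)c1ccc([N+](=O)[O-])cc1` gives 10.7 nM and compound 3 `O=C(Nc1cc(-c2ccccc2)nn1-c1ccccc1)c1ccc(Cl)c(Cl)c1` gives 13 nM; both changes sit on the carbonyl side of the core: a 19-fold lower number from compound 1 to compound 2 (1.28 log units; beyond the scatter) and a 16-fold lower number from compound 1 to compound 3 (1.19 log units; beyond the scatter), while a 1.2-fold higher number from compound 2 to compound 3 (0.08 log units; within the scatter). Within the data shown here, compound 4 `O=C(Nc1cc(-c2ccccc2)nn1-c1ccccc1F)c1ccccc1` differs from compound 1 by fluoro in place of hydrogen on an aromatic carbon, on the ring attached to the ring nitrogen of the core, a position no measured step touches. The large steps from compound 1 concern the carbonyl-side ring only and do not bear on this change; a single fluoro entering elsewhere gives no reason to expect more than a step within the scatter. For compound 4 the expected value is 200 nM (range 70 nM to 600 nM). Relative to compound 1 this estimate means a 1.0-fold lower number from compound 1 to compound 4 (0.01 log units; within the scatter) is expected.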

Compound 4, half-maximal effective concentration: 104 nM
The estimate for compound 4 lay 1.9-fold (0.28 log units) above the measured number, within the range that was stated.
By their numbers in this assay, from the lowest: compounds 2 and 3 (each within the scatter of the next); then compounds 4 and 1 (each within the scatter of the next).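

Within the data shown here, compound 4 is the first compound changed on this ring: phenyl to 2-fluorophenyl, with fluoro ortho to a large group, gives a 2.0-fold lower number from compound 1 to compound 4 (0.29 log units; within the scatter). This position therefore accepts a single fluoro without a step beyond the scatter, so the ring can carry this small change. No measurement bears on why the number stays within the scatter.

On these data alone, whether the same position takes a larger group, such as a methoxy, an amine or a carboxylic acid, remains open. Also open, as far as these compounds go, is whether fluoro here combines with the nitro of compound 2 or the 3,4-dichlorophenyl of compound 3.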